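The compounds below may be only part of what the source reports. "The series", "measured", "known", "first", "only" and "open" are said of these compounds alone.

- Compound 1 `CC(C)Sc1nc(O)cc(C(C)c2ccccc2)n1`: > 200000 nM (a limit)
- Compound 2 `CCC(c1ccccc1)c1cc(O)nc(SC(C)C)n1`: > 200000 nM (a limit)
- Compound 3 `CC(c1ccccc1)c1cc(O)nc(SC2CCCCC2)n1`: not yet measured

In a functional assay on MT4 cells (Homo sapiens) for cytotoxicity (a lower number here means that less compound is tolerated, a higher number that more compound is tolerated), compound 1 gives only a limit, with no number behind it, and stands at the limit of > 200000 nM in this assay, at which 2 of the 2 values shown sit. Compound 3 differs from it as follows: cyclohexyl in place of isopropyl on a sulfur. This places cyclohexyl in place of isopropyl on a sulfur. Among the compounds with values here, the only measured step, a step that the two limits leave unreadable from compound 1 to compound 2, lies elsewhere in the molecule and gives no size to carry over. Only a small step towards less compound tolerated is therefore expected in this assay. The expected step is an at least 1.3-fold lower number from compound 1 to compound 3 (0.12 log units; that floor lies within the scatter). Compound 3 is estimated at 150000 nM, within an expected range of 50000 nM to 200000 nM.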

Compound 3, half-maximal cytotoxic concentration: 149000 nM
The estimate for compound 3 lay 1.0-fold (0.00 log units) above the measured number, and the stated range covers the measured number.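

In this assay, within the data shown here, compound 3 is the first of the three to give a number rather than a limit: compound 3 gives 149000 nM. Cyclohexyl in place of isopropyl on a sulfur can therefore be read as an at least 1.3-fold lower number from compound 1 to compound 3 (0.12 log units; that floor lies within the scatter), while the step at the other position cannot be read. This step is only a floor, as its starting point is a limit: the limit of > 200000 nM in this assay, at which 2 of the 3 values shown sit.

From the compounds shown here alone, how far the true step extends stays open. So does what a phenyl group or a longer chain on the sulfur would give in this assay.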